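This account rests on a few compounds, and the source may have more. Where it says the series, first, only, none or still open, it means among the compounds named here.

Measured in a functional assay on HepG2 cells (Homo sapiens) for inhibition, read by MTT assay, with a stated time of 48 h; a lower number here means a stronger inhibitor, a higher number a weaker inhibitor:
- Compound 1 `COc1ccc(C(=O)C=CNc2cc(-c3ccccc3)nn2-c2ccccc2)cc1`: 2030 nM
- Compound 2 `O=C(C=CNc1cc(-c2ccccc2)nn1-c1ccccc1)c1ccc(Br)cc1`: 8810 nM
- Compound 3 `O=C(C=CNc1cc(-c2ccccc2)nn1-c1ccccc1)c1cccs1`: 2420 nM

Two steps fix the place of compound 3 among these numbers: a 1.2-fold higher number from compound 1 to compound 3 (0.08 log units; within the scatter), and a 3.6-fold lower number from compound 2 to compound 3 (0.56 log units; beyond the scatter). Compound 4 `O=C(C=CNc1cc(-c2ccccc2)nn1-c1ccccc1)c1ccccc1` differs from compound 3 by phenyl in place of thiophen-2-yl on a carbonyl carbon. The same two steps bear on this change, since each exchanges thiophen-2-yl for a substituted phenyl at that carbon. One stays within the scatter and the other is modest, and no unsubstituted phenyl has yet been measured. A small rise in this assay, probably within the scatter, is therefore expected. The expected change is a 1.3-fold higher number from compound 3 to compound 4 (0.12 log units; within the scatter). Compound 4 is estimated at 3200 nM, with an expected range of 1400 nM to 7500 nM.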

Compound 4, half-maximal inhibitory concentration: 2660 nM
Estimate against measurement, compound 4: 1.2-fold (0.08 log units) above; measured number inside the range.
By their numbers in this assay, from the lowest: compounds 1, 3 and 4 (each within the scatter of the next); then compound 2.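

In this assay, unsubstituted phenyl and thiophen-2-yl on this carbonyl carbon cannot be told apart (a 1.1-fold higher number from compound 3 to compound 4 (0.04 log units; within the scatter)). On the aromatic carbon, hydrogen likewise cannot be told apart from methoxy (a 1.3-fold higher number from compound 1 to compound 4 (0.12 log units; within the scatter)), but it does differ from bromo (a 3.3-fold lower number from compound 2 to compound 4 (0.52 log units; beyond the scatter)). The higher number therefore goes with the bromo compound alone among these four, not with the phenyl ring as such, and nothing here gives a cause for that gap. Still open, on these data alone, is whether an amine or a carboxylic acid on that aromatic carbon would stay with hydrogen and methoxy or move toward bromo.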